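The source may hold more compounds than are shown below. What is called first, only, known or untested is meant among the compounds shown, and "the series" means these compounds.

Measured so far in an ADME assay (Rattus norvegicus, strain Wistar Han) for pharmacokinetics; a higher number here means that more of the compound sits outside the plasma, a lower number that more of the compound stays in the plasma:
compound 1 `CCn1c(-c2cnc(C)nc2)nc2c(N[C@H]3CCN(C(=O)C4CCC4)C3)ncnc21`: 0.5 L/kg
compound 2 `CCn1c(-c2cnc(C)nc2)nc2c(O[C@H]3CCN(C(=O)C4CCC4)C3)ncnc21`: 0.6 L/kg
compound 3 `CCn1c(-c2ccc(C(F)(F)F)nc2)nc2c(O[C@H]3CCN(C(=O)[C@H]4C[C@@H](OC)C4)C3)ncnc21`: 0.4 L/kg

All three numbers in this assay fall within the usual scatter of one another. Compound 1 lies within the scatter of compound 2, which differs from it in the linker to the shared core, and within the scatter of compound 3, which carries a different aryl group, a different substituent on the cyclobutyl and a different linker. On the numbers shown, compound 1 cannot be told apart from either of them; the series so far gives no step beyond the scatter that would point to a structural handle on this read-out.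

Compound 4 `CCC(=O)N1CC[C@H](Nc2ncnc3c2nc(-c2cnc(C)nc2)n3CC)C1` has not yet been measured in this assay. Relative to compound 1 the change is ethyl in place of cyclobutyl on a carbonyl carbon. The amide-type nitrogen in the ring and everything else in compound 1 is kept. Among the compounds with values here, nothing measured so far separates two compounds that differ only at the carbonyl substituent, and the three measured compounds, with larger differences among them, all sit within the scatter. The expectation is therefore a step of no change at the digits printed from compound 1 to compound 4 (within the scatter) of no size beyond the scatter, in no particular direction. For compound 4 the estimate in this assay is 0.5 L/kg, with a range from 0.3 L/kg to 0.9 L/kg.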

Compound 4, volume of distribution: 1 L/kg
Estimate against measurement, compound 4: 2.0-fold (0.30 log units) below; the measured number lies above the stated range.
By their numbers in this assay, from the lowest: compounds 3, 1, 2 and 4 (each within the scatter of the next, the first and the last beyond it).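

In this assay, within the data shown here, ethyl in place of cyclobutyl on a carbonyl carbon gives the first step that isolates a single position: a 2.0-fold higher number from compound 1 to compound 4 (0.30 log units; within the scatter). The exchange removes the four-membered ring and two heavy atoms from this position, yet the step does not pass the usual scatter, so this pair gives no firm evidence that the carbonyl substituent controls the read-out. No measurement at hand bears on the size of this step, and the data offer no explanation for it.

The series still leaves open whether this position can move the read-out beyond the scatter when the group on the carbonyl carbon is something other than a small carbon substituent, such as a longer chain, a dimethylamino group or a carboxylic acid. It also leaves open whether ethyl in place of cyclobutyl gives a comparable step when the linker of compound 2 is kept, and a single pair cannot show how far the step at this position carries over to other members of the series.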